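The compounds below may be only part of what the source reports. "The series", "measured", "known", "first", "only" and "open" are said of these compounds alone.

Compound 1, `O=c1ccc(-c2ccccc2)nn1CCCCNC(=S)Nc1ccc(Cl)cc1`: > 100 mg/kg
Compound 2, `C/N=C(/NC#N)NCCCCn1nc(-c2ccccc2)c(C)cc1=O`: > 100 mg/kg

In a functional assay on the whole organism (stomach) with Rattus norvegicus as the target (on this read-out higher numbers stand for an effect only at larger amounts of compound and lower numbers for an effect already at smaller amounts), compound 1 gives > 100 mg/kg, which is a limit of the assay and not a number. Compound 2 gives > 100 mg/kg, also a limit. Both values sit at the limit of > 100 mg/kg in this assay, at which 2 of the 2 values shown sit, so compound 1 stands at the limit with no number of its own. Compound 3, `C=CCNC(=S)NCCCCn1nc(-c2ccccc2)ccc1=O`, differs from compound 1 by allyl in place of 4-chlorophenyl on an amide-type nitrogen. Among the measured compounds shown here, no measured step between compounds exists here, so the step that the limit leaves unreadable from compound 1 to compound 3 is expected to be none beyond the usual scatter, leaving compound 3 near the limit. Compound 3 is estimated at 150 mg/kg, between 50 mg/kg and 500 mg/kg.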

Compound 3, dose for half-maximal effect: > 100 mg/kg
Compound 3: only a limit was reported (the forecaster's own chance of this, stated with the estimate: 80%); the middle value does not contradict the limit.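

No step can be read from compound 1 to compound 3, because both values are limits and not numbers: the limit of > 100 mg/kg in this assay, at which 3 of the 3 values shown sit. The compounds shown leave open what dose in this assay would give a half-maximal effect for either compound, and so whether allyl and 4-chlorophenyl differ at all.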